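Chloro to Bromo on the Aryl Ketone of Compound 1

This account rests on a few compounds, and the source may have more. Where it says the series, first, only, none or still open, it means among the compounds named here.

Compound 1 `O=C(C=CNc1cc(-c2ccccc2)nn1-c1ccccc1)c1ccc(Cl)cc1` was tested in a functional assay on HepG2 cells (Homo sapiens) for inhibition, read by MTT assay, with a stated time of 48 h (a lower number here means a stronger inhibitor, a higher number a weaker inhibitor), where compound 1 gives 41200 nM. That is the highest of the three numbers measured in this set. Compound 2 `c1ccc(-c2nn(-c3ccccc3)c3nccc(-c4cccs4)c23)cc1` gives 39300 nM, and the two values sit within the scatter of each other, so nothing separates them. Compound 3 `COc1ccc(-c2ccnc3c2c(-c2ccccc2)nn3-c2ccccc2)cc1` gives 6590 nM, and the step of a 6.0-fold lower number from compound 2 to compound 3 (0.78 log units; beyond the scatter) is the only measured step among these compounds. Compound 4 `O=C(C=CNc1cc(-c2ccccc2)nn1-c1ccccc1)c1ccc(Br)cc1` differs from compound 1 in one place: bromo in place of chloro on an aromatic carbon. For the measured compounds named here, no measured step touches this change; the one step that is known concerns a different core and a different position, so it does not bear on compound 4. With one halogen exchanged for another and the rest of the molecule unchanged, the expected step of a 1.1-fold lower number from compound 1 to compound 4 (0.06 log units; within the scatter) is none beyond the scatter, in either direction. Compound 4 is therefore estimated at 36000 nM, with a range from 15000 nM to 85000 nM.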

Compound 4, half-maximal inhibitory concentration: 8810 nM
Beside the measured number, compound 4's estimate is 4.1-fold (0.61 log units) above it; measured number below the stated range.
By their numbers in this assay, from the lowest: compounds 3 and 4 (each within the scatter of the next); then compounds 2 and 1 (each within the scatter of the next).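

In this assay, for the compounds shown here, the exchange of bromo for chloro on the aromatic carbon of the aryl ketone gives a 4.7-fold lower number from compound 1 to compound 4 (0.67 log units; beyond the scatter) even though only one heavy atom changes, and no ring, hydrogen-bond donor, hydrogen-bond acceptor or net charge enters or leaves. Going by these compounds alone, the earlier compounds offered no step at this position, so this is the first measured sign that the number responds to the halogen held on this six-membered aromatic ring. Within the data shown here, the only other measured step concerns a different core and a different position, so the two steps cannot be set against each other.

As far as these compounds go, whether fluoro, iodo, methyl or an amine at this carbon would move the number further, or back, remains open. No available measurement accounts for the step itself.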